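The compounds below may be only part of what the source reports. "The series", "measured", "known", "first", "only" and "open" are said of these compounds alone.

Of the compounds shown here, three have so far been measured in a functional assay on EA.hy 926 cells (Homo sapiens) for cytotoxicity, read by MTT assay, with stated times of 24 h and 12 h, tested at 100 uM; on this read-out lower numbers stand for a weaker effect and higher numbers for a stronger effect at the one concentration tested. Compound 1 `COc1ccc(OC(=O)c2nc(C)c(C)nc2C)c(/C=C/C(=O)O)c1` gives 79.2% in this assay. Compound 2 `COc1cc(/C=C/C(=O)O)cc(OC)c1OC(=O)c1nc(C)c(C)nc1C` gives 163% there, and compound 3 `CCOC(=O)/C=C/c1cc(OC)c(OC(=O)c2nc(C)c(C)nc2C)c(OC)c1` gives -47%. Compound 1 thus stands second highest of the three, and its gaps to both compound 2 and compound 3 lie beyond the usual scatter of this kind of measurement. How the core of compound 1 differs from that of compound 2 is not broken down here. Compound 3 is compound 2 with a single change, (ethyl in place of hydrogen on an oxygen next to a carbonyl group), and that change made the step of a number 210 percentage points lower from compound 2 to compound 3 (beyond the scatter), a large step well beyond the scatter.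

Compound 4 `CCOC(=O)/C=C/c1cc(OC)ccc1OC(=O)c1nc(C)c(C)nc1C` has not yet been measured in this assay. For the measured compounds named here, it differs from compound 1 by ethyl in place of hydrogen on an oxygen next to a carbonyl group, the same change at the same place as the one that turned compound 2 into compound 3. Going by the values given here, whether the change acts the same way on the core of compound 1 cannot be known from a single example, and only that one step speaks for it. Compound 4 is nevertheless expected to take the step of a number 114.2 percentage points lower from compound 1 to compound 4 (beyond the scatter), because the earlier step of a number 210 percentage points lower from compound 2 to compound 3 (beyond the scatter) was so large. Compound 4 is estimated to give -35% in this assay, with the expected range running from -100% to 30%.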

Compound 4, a percentage reported as activity, at one concentration (the size of the read-out at that concentration, not a potency): 46.2%
Estimate against measurement, compound 4: 81.2 percentage points below; measured number above the stated range.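

Ethyl in place of hydrogen on an oxygen next to a carbonyl group again lowers the number in this assay, this time by a number 33 percentage points lower from compound 1 to compound 4 (beyond the scatter), so the direction of the change is the same on both cores shown, but its size does not carry over from one core to the other: the same change on two cores in this assay, a number 210 percentage points lower (beyond the scatter) from compound 2 to compound 3 and a number 33 percentage points lower (beyond the scatter) from compound 1 to compound 4, 177 percentage points apart, beyond the scatter of two such steps In this series, then, the step seen on one core gave the likely sign of the step on the other but was a poor guide to its size, and that statement rests on just these two pairs of compounds. The two pairs do not show what in the cores separates the steps, nor whether the same direction would hold on any further core, and they say nothing about the reason for the lower numbers.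

The compounds shown leave open how a methyl group or a longer chain such as propyl or butyl would behave on that oxygen, and whether an amide in place of the ester would follow the ethyl ester or the carboxylic acid. They also leave open whether the gap between the two steps would persist at concentrations other than the single one tested.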